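This account rests on a few compounds, and the source may have more. Where it says the series, first, only, none or still open, it means among the compounds named here.

Measured so far in a physicochemical assay for solubility, read by spectrophotometry, with a stated time of 24 h, at pH 7.4; a lower number here means a less soluble compound, a higher number a more soluble compound:
- Compound 1 `CN(C)c1ccc(C(=O)N/N=C/c2ccc(C(=O)O)cc2)cc1`: > 77000 nM (a limit)
- Compound 2 `CN(/N=C/c1ccc(C(=O)O)cc1)C(=O)c1ccc(N(C)C)cc1`: > 67000 nM (a limit)

Neither compound has an exact number. Compound 2 stands only at its limit of > 67000 nM. For the measured compounds named here, the one other value shown, for compound 1, is also a limit, > 77000 nM.

The next compound, compound 3 `CN(/N=C/c1ccc(C(=O)NO)cc1)C(=O)c1ccc(N(C)C)cc1`, keeps the core of compound 2 and changes one group: hydroxyamino in place of hydroxy on a carbonyl carbon. Put simply, hydroxyamino takes the place of hydroxy on a carbonyl carbon, turning carboxy into hydroxycarbamoyl.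

Going by the values given here, only one measured step is available as a guide: a step that the two limits leave unreadable from compound 1 to compound 2. It is a different change, methyl in place of hydrogen on an amide-type nitrogen, and it gives no size to carry over. No measured step sizes the swap from carboxy to hydroxycarbamoyl, so the expectation here is cautious and the range wide.

The expected change is an at least 1.9-fold lower number from compound 2 to compound 3 (0.28 log units; that floor lies within the scatter), a moderate fall in this assay that remains an estimate. Compound 3 could also return only a limit. For compound 3, the estimated value is 35000 nM, with an expected range from 8000 nM to 70000 nM.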

Compound 3, solubility: > 64000 nM
Compound 3 ended at the assay's limit; the forecaster's own chance of this, stated with the estimate: 40%; at least 1.8-fold (0.26 log units) between middle value and limit.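

In this assay, compound 3 gives > 64000 nM, which is a limit and not an exact number. Compound 2 gives > 67000 nM, also a limit, and the step between compound 2 and compound 3 cannot be read. The compounds shown leave open whether hydroxycarbamoyl in place of carboxy changes the read-out at all, and by how much.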